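Dithiocarbamate chromone series: amine swap at the thiocarbonyl

The source may report more compounds than this note shows. Statements on the series, on what has been measured and on what is new or still open speak of the compounds shown alone.

Measured compounds:
- compound 1 `O=c1cc(CSC(=S)N2CCCC2)oc2cc(Cl)ccc12` — > 25000 nM
- compound 2 `O=c1c(CSC(=S)N2CCOCC2)coc2cc(Cl)ccc12` — 6200 nM
- compound 3 `O=c1c(CSC(=S)N2CCOCC2)coc2ccccc12` — 5900 nM

In a functional assay on SW480 cells (Homo sapiens) for antiproliferative activity, read by MTT assay, with a stated time of 72 h (on this read-out lower numbers stand for stronger inhibition and higher numbers for weaker inhibition), compound 1 gives > 25000 nM, which is a limit of the assay and not a number (the limit of > 25000 nM in this assay, at which 1 of the 3 values shown sits). Compound 2 gives 6200 nM, the higher of the two numbers shown, with compound 3 its nearest neighbour. Within the data shown here, the only step between measured compounds, a 1.1-fold lower number from compound 2 to compound 3 (0.02 log units; within the scatter), concerns hydrogen in place of chloro on an aromatic carbon and is within the scatter.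

Compound 4 `CC(C)N(C(=S)SCc1coc2cc(Cl)ccc2c1=O)C(C)C` is not yet measured. It differs from compound 2 by diisopropylamino in place of morpholin-4-yl on a thiocarbonyl carbon. Among the measured compounds shown here, no measured step touches the substituent on the thiocarbonyl carbon: the step from compound 2 to compound 3 changes only the aromatic substituent, and compound 1 differs from compound 2 in more than one place, so only its limit and the number for compound 2 can be set side by side. The size of the effect of diisopropylamino in place of morpholin-4-yl is therefore open.

Given this, compound 4 is expected to give a number close to that of compound 2, with a step of a 1.0-fold lower number from compound 2 to compound 4 (0.01 log units; within the scatter) and a wide range. The estimate for compound 4 in this assay is 6000 nM, between 2000 nM and 20000 nM.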

Compound 4, half-maximal inhibitory concentration: > 25000 nM
Compound 4: a limit, no number; the forecaster's own chance of this, stated with the estimate: 20%; middle value at least 4.1-fold (0.61 log units) from the limit.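

Notes on the amine at the thiocarbonyl carbon: in this assay, diisopropylamino in place of morpholin-4-yl gives an at least 4.0-fold higher number from compound 2 to compound 4 (0.60 log units; beyond the scatter), the first single change in the series to go beyond the scatter, while the change on the aromatic carbon, a 1.1-fold lower number from compound 2 to compound 3 (0.02 log units; within the scatter), stays within it. Compound 4 stands at a limit of the assay and not a number, so this step has a lower bound but no measured size: the limit of > 25000 nM in this assay, at which 2 of the 4 values shown sit.

On a thiocarbonyl carbon, then, the choice of amine is not neutral: with morpholin-4-yl the series keeps a measurable number, and with diisopropylamino it does not.

Compound 1 is also a limit, but it differs from compound 2 in more than one place and so cannot show what its amine alone contributes. Still open, as far as these compounds go, is whether the ring, its oxygen or the branched chains decide the outcome at this carbon: piperidin-1-yl on the same core would test a ring without the oxygen, and dimethylamino or diethylamino would test open chains without the branching.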